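The compounds below may be only part of what the source reports. "The series", "measured", "known", "first", "only" and "open" are said of these compounds alone.

Working notes on the series. Compound 1 `Cc1ccc(C(=O)NC(=S)NNc2ncnc3ccccc23)cc1` gives the highest number of the three measured in a functional assay on KB cells (Homo sapiens) for cytotoxicity, read by MTT assay, with a stated time of 72 h; on this read-out higher numbers stand for weaker inhibition and lower numbers for stronger inhibition: compound 1 shows 10100 nM, the weakest inhibition of the set. Compound 2 `COc1cc2ncnc(NNC(=S)NC(=O)c3ccccc3)c2cc1OC` shows 3770 nM, and compound 3 `COc1cc2ncnc(NNC(=S)NC(=O)c3ccccc3Cl)c2cc1OC` shows 3560 nM, both beyond the scatter from compound 1. The move to compound 4 `O=C(NC(=S)NNc1ncnc2ccccc12)c1ccc(Cl)cc1` is chloro in place of methyl on an aromatic carbon. Among the compounds with values here, the only measured step that bears on it is the chloro in place of hydrogen on an aromatic carbon, elsewhere in the molecule: a 1.1-fold lower number from compound 2 to compound 3 (0.02 log units; within the scatter). That step replaced hydrogen rather than methyl, so the guidance is loose, and no step beyond the scatter is expected, a 1.1-fold lower number from compound 1 to compound 4 (0.05 log units; within the scatter). Compound 4 is therefore estimated at 9000 nM, within 4000 nM to 22000 nM.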

Compound 4, half-maximal inhibitory concentration: 3940 nM
Estimate against measurement, compound 4: 2.3-fold (0.36 log units) above, outside the stated range (below it).
By their numbers in this assay, from the lowest: compounds 3, 2 and 4 (each within the scatter of the next); then compound 1.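

In this assay, going from 4-methylphenyl to 4-chlorophenyl gives a step beyond the scatter (a 2.6-fold lower number from compound 1 to compound 4 (0.41 log units; beyond the scatter)). This position, para to a large group, therefore responds to the exchange of methyl for chloro, whereas chloro in place of hydrogen elsewhere in the molecule stayed within the scatter (a 1.1-fold lower number from compound 2 to compound 3 (0.02 log units; within the scatter)). No measurement at hand accounts for the step. Open, on these data alone, is how an amine or a carboxylic acid at this position would read, and whether the same exchange carries over to the core of compound 2.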